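Swapping Methyl for Fluoro on the Benzyl Ring

A few compounds are considered here, and "the series" means these few. Any claim that something is new, unique, unknown or untested is made for them only; others in the source may bear on it.

compound 1 `O=[N+]([O-])c1cccc(CSc2nnc(-c3ccc4c(c3)OCCO4)n2-c2ccccc2)c1`: 7590 nM
compound 2 `COc1cccc(CSc2nnc(-c3ccc4c(c3)OCCO4)n2-c2ccccc2)c1`: 10100 nM
compound 3 `Cc1ccc(CSc2nnc(-c3ccc4c(c3)OCCO4)n2-c2ccccc2)cc1`: 16200 nM

All three compounds share one core and differ only in the substituted benzyl group on sulfur. They were tested in a functional assay on SW 1116 cells (Homo sapiens) for antiproliferative activity, read by MTT assay, with a stated time of 24 h; a lower number here means a stronger inhibitor, a higher number a weaker inhibitor. There, compound 3 gives 16200 nM. The data show a 2.1-fold higher number from compound 1 to compound 3 (0.33 log units; beyond the scatter) and a 1.6-fold higher number from compound 2 to compound 3 (0.21 log units; within the scatter), so compound 3 stands apart from compound 1 but cannot be told apart from compound 2.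

The next compound, compound 4 `Fc1ccc(CSc2nnc(-c3ccc4c(c3)OCCO4)n2-c2ccccc2)cc1`, has fluoro in place of methyl on an aromatic carbon, para to a large group: fluoro in place of methyl on an aromatic carbon. Among the compounds with values here, no measured pair makes this exact swap, so the evidence is indirect. The nearest guide is that changing this benzyl group has moved the number only modestly so far, with a 1.3-fold higher number from compound 1 to compound 2 (0.12 log units; within the scatter) as the third example. A large jump therefore seems unlikely, and no step beyond the scatter is expected. The expected change is a 1.4-fold lower number from compound 3 to compound 4 (0.13 log units; within the scatter). For compound 4 the estimated value is 12000 nM, with an expected range from 6000 nM to 24000 nM.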

Compound 4, half-maximal inhibitory concentration: 20800 nM
The estimate for compound 4 lay 1.7-fold (0.24 log units) below the measured number; the range from low to high includes it.
By their numbers in this assay, from the lowest: compounds 1, 2, 3 and 4 (each within the scatter of the next, the first and the last beyond it).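

In this assay, fluoro in place of methyl on this aromatic carbon, para to a large group, gives a step too small to count (a 1.3-fold higher number from compound 3 to compound 4 (0.11 log units; within the scatter)), so the number does not respond measurably to this swap. Compound 4 does stand apart from the two other benzyl compounds (a 2.1-fold higher number from compound 2 to compound 4 (0.31 log units; beyond the scatter) and a 2.7-fold higher number from compound 1 to compound 4 (0.44 log units; beyond the scatter)), and the gap to compound 2 is one that compound 3 did not show, although compound 3 and compound 4 themselves cannot be told apart. Nothing measured here gives a reason for these steps.

The compounds shown leave open whether an amine or a carboxylic acid in place of the fluoro would move the number beyond the scatter. They also leave open what a longer chain in place of the benzyl group would do.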